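Aryl substituent exchange toward compound 4 in the series

The source may report more compounds than this note shows. Statements on the series, on what has been measured and on what is new or still open speak of the compounds shown alone.

The members share one core and differ only in the aromatic ring attached to the five-membered ring. Compound 1 `Cc1ccc(-c2nnc(COc3cnn(C(C)(C)C)c(=O)c3Cl)o2)cc1` gives 19.9 ug/mL in a functional assay on the whole organism for inhibition, with Mythimna separata as the target, with a stated time of 5 days; on this read-out higher numbers stand for an effect only at larger amounts of compound and lower numbers for an effect already at smaller amounts. Compound 2 `CC(C)(C)n1ncc(OCc2nnc(-c3ccc(F)cc3)o2)c(Cl)c1=O` carries fluoro in place of methyl and gives 5.2 ug/mL in this assay; the step is a 3.8-fold lower number from compound 1 to compound 2 (0.58 log units; beyond the scatter). Compound 3 `CC(C)(C)n1ncc(OCc2nnc(-c3ccc([N+](=O)[O-])cc3)o2)c(Cl)c1=O` carries the nitro group. In this assay compound 3 reports only a limit, > 300 ug/mL, which is a limit of the assay rather than a number (the limit of > 300 ug/mL in this assay, at which 1 of the 3 values shown sits). Among the compounds with values here, compound 3 therefore stands at the weak end of the three measured members, since an at least 15-fold higher number from compound 1 to compound 3 (1.17 log units; beyond the scatter) and an at least 57-fold higher number from compound 2 to compound 3 (1.76 log units; beyond the scatter).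

Compound 4 `CC(C)(C)n1ncc(OCc2nnc(-c3ccc(Cl)cc3Cl)o2)c(Cl)c1=O` differs from compound 3 by 2,4-dichlorophenyl in place of 4-nitrophenyl on an aromatic carbon. Within the data shown here, no measured step covers this exact exchange. Among the measured compounds shown here, the steps that bear on it are the two leading into compound 3, both large and both toward higher numbers, and the modest step from methyl to fluoro toward lower numbers. Leaving the nitro group is expected to reverse a large step, an at least 30-fold lower number from compound 3 to compound 4 (1.47 log units; beyond the scatter). Compound 4 is estimated at 10 ug/mL in this assay, with a range from 3 ug/mL to 60 ug/mL.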

Compound 4, half-maximal effective concentration: 27.8 ug/mL
Beside the measured number, compound 4's estimate is 2.8-fold (0.44 log units) below it, within the range that was stated.
By their numbers in this assay, from the lowest: compound 2; then compounds 1 and 4 (each within the scatter of the next). At a limit, above all of these: compound 3.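

Compound 3 remains a limit of the assay and not a number: (the limit of > 300 ug/mL in this assay, at which 1 of the 4 values shown sits). With that reservation, the exchange on this aromatic carbon of the five-membered ring gives a large change in this assay (an at least 10-fold lower number from compound 3 to compound 4 (1.03 log units; beyond the scatter)), so a measured number returns with 2,4-dichlorophenyl, an aryl group bearing two chlorine atoms and no nitro group. The earlier members carried a single group on the phenyl ring, and this one separates from them unevenly: it lies modestly on the weaker side of the 4-fluorophenyl member (a 5.3-fold higher number from compound 2 to compound 4 (0.73 log units; beyond the scatter)), while it cannot be told apart from the 4-methylphenyl member (a 1.4-fold higher number from compound 1 to compound 4 (0.15 log units; within the scatter)), which leaves compound 2 alone at the low-number end of the four.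

The compounds shown leave open what each chlorine contributes, since 2,4-dichlorophenyl differs from 4-fluorophenyl in both the halogen and the number of groups on the ring, and a 4-chlorophenyl member would separate the two. As far as these compounds go, how a methoxy group, an amine or a carboxylic acid on this phenyl ring would read also stays open.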